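The source may report more compounds than this note shows. Statements on the series, on what has been measured and on what is new or still open speak of the compounds shown alone.

Compound 1 `Cn1nc2c(=O)n(CC3(O)CCN(Cc4ccc(-c5ccco5)cc4Cl)CC3)cnc2c1-c1ccc(C2(N)CC2)cc1` has the shortest half-life of the three compounds measured in an ADME assay on microsomes from liver (Rattus norvegicus) for metabolic stability; on this read-out lower numbers stand for a shorter-lived compound and higher numbers for a longer-lived compound. In this assay compound 1 gives 0.617 h, while compound 2 `Cn1nc2c(=O)n(CC3(O)CCN(Cc4ccc(-c5ccco5)cc4Cl)CC3)cnc2c1-c1ccc(CNCCO)cc1` gives 1.52 h and compound 3 `Cn1nc2c(=O)n(CC3(O)CCN(Cc4ccc(-c5cccs5)cc4Cl)CC3)cnc2c1-c1ccc(CN)cc1` gives 1.38 h. Within the data shown here, the only single change measured so far is a 2.5-fold higher number from compound 1 to compound 2 (0.39 log units; beyond the scatter), where a larger, chain-bearing group replaces the small ring. Compound 4 `Cn1nc2c(=O)n(CC3(O)CCN(Cc4ccc(-c5ccco5)cc4Cl)CC3)cnc2c1-c1ccc(CN)cc1` takes a related step from compound 1: aminomethyl in place of 1-aminocyclopropyl on an aromatic carbon. Compound 3 also carries aminomethyl, though it differs from compound 4 in another place, and its value stands well above that of compound 1. Both observations point the same way: removing 1-aminocyclopropyl in favour of an open aminomethyl group is expected to lengthen the half-life, roughly as seen from compound 1 to compound 2. Compound 4 is therefore expected to last longer in this assay, with an estimated step of a 2.1-fold higher number from compound 1 to compound 4 (0.32 log units; beyond the scatter). The estimate for compound 4 is 1.3 h, within a range of 0.7 h to 2.5 h.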

Compound 4, half-life: 2.37 h
Compound 4: middle estimate off by 1.8-fold (0.26 log units), on the low side; the measured number falls inside the stated range.
By their numbers in this assay, from the lowest: compound 1; then compounds 3, 2 and 4 (each within the scatter of the next).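

With the furan-2-yl group held constant, replacing 1-aminocyclopropyl with aminomethyl at this position, para to a large group, gives a 3.8-fold higher number from compound 1 to compound 4 (0.58 log units; beyond the scatter) in this assay, a direct single-place comparison of these two groups. The longer half-life does not depend on a 2-hydroxyethyl group on the amine nitrogen, since removing it gives a 1.6-fold higher number from compound 2 to compound 4 (0.19 log units; within the scatter), and furan-2-yl and thiophen-2-yl cannot be told apart in this pair, with a 1.7-fold higher number from compound 3 to compound 4 (0.23 log units; within the scatter). Nothing measured here explains the difference between 1-aminocyclopropyl and aminomethyl.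

Going by these compounds, it remains open whether the ring itself matters, or whether an open-chain 2-aminopropan-2-yl group would behave like 1-aminocyclopropyl. The compounds shown also leave open how a longer chain, such as 2-aminoethyl, would fare at this position.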